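This account rests on a few compounds, and the source may have more. Where it says the series, first, only, none or still open, it means among the compounds named here.

For the measured compounds named here, compound 3 `C#CCOC(=O)/C(C)=C/CC/C(C)=C/CC/C(C)=C/CC[C@@H]1[C@@]2(C)CCC(=O)C(C)(C)[C@H]2CC[C@@]1(C)O` is the only measured compound with a true number in a functional assay on A549 cells (Homo sapiens) for antiproliferative activity, read by MTT assay, with a stated time of 48 h (a higher number here means a weaker inhibitor, a lower number a stronger inhibitor), where compound 3 gives 45100 nM. Compound 1 `C/C(=C\CC/C(C)=C/CC[C@@H]1[C@@]2(C)CCC(=O)C(C)(C)[C@H]2CC[C@@]1(C)O)CC/C=C(\C)C(=O)OCc1cn(-c2ccccc2C(F)(F)F)nn1` gives > 150000 nM, which is a limit of the assay and not a number. Compound 2 `C/C(=C\CC/C(C)=C/CC[C@@H]1[C@@]2(C)CCC(=O)C(C)(C)[C@H]2CC[C@@]1(C)O)CC/C=C(\C)C(=O)OCc1cn(-c2ccccc2Br)nn1` gives > 150000 nM, which is also a limit. Both results stand at the same mark: the limit of > 150000 nM in this assay, at which 2 of the 3 values shown sit. The comparison between them is a step that the two limits leave unreadable from compound 1 to compound 2, so it offers no size to work from.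

The useful guide is an at least 3.3-fold lower number from compound 2 to compound 3 (0.52 log units; beyond the scatter), seen when ethynyl replaces 1-(2-bromophenyl)-1H-1,2,3-triazol-4-yl. Compound 4 `C/C(=C\CC/C(C)=C/CC[C@@H]1[C@@]2(C)CCC(=O)C(C)(C)[C@H]2CC[C@@]1(C)O)CC/C=C(\C)C(=O)OCc1cn(-c2cccc(Cl)c2)nn1` runs the same kind of change in reverse, with a different aromatic substituent: 1-(3-chlorophenyl)-1H-1,2,3-triazol-4-yl in place of ethynyl on a saturated chain carbon bound to an oxygen next to a carbonyl group. Here, 1-(3-chlorophenyl)-1H-1,2,3-triazol-4-yl replaces ethynyl on a saturated chain carbon bound to an oxygen next to a carbonyl group. A rise in this assay beyond the scatter is therefore expected, and the result may well stop at the limit. The expected change is a 2.9-fold higher number from compound 3 to compound 4 (0.46 log units; beyond the scatter). The estimate for compound 4 is 130000 nM, within an expected range of 50000 nM to 300000 nM.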

Compound 4, half-maximal inhibitory concentration: 147000 nM
Compound 4: the middle estimate sits 1.1-fold (0.05 log units) below what was measured, and the stated range covers the measured number.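

In this assay, placing 1-(3-chlorophenyl)-1H-1,2,3-triazol-4-yl on this saturated chain carbon now has a true size, with a number at both ends of the pair: a 3.3-fold higher number from compound 3 to compound 4 (0.51 log units; beyond the scatter). The earlier triazole compounds could give only a floor for this kind of change, as neither reached a true number. Changing the aromatic group on the triazole nitrogen gives an at least 1.0-fold lower number from compound 2 to compound 4 (0.00 log units; that floor lies within the scatter) and an at least 1.0-fold lower number from compound 1 to compound 4 (0.00 log units; that floor lies within the scatter), so no difference among these aromatic groups can be claimed, and the comparison is capped: the limit of > 150000 nM in this assay, at which 2 of the 4 values shown sit.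

Still open, from the compounds shown here alone, is which part of the entering group, the triazole or the 3-chlorophenyl, carries the step. Going by these compounds, it is also open whether an amine or a carboxylic acid in place of the chlorine, or a longer chain in place of ethynyl, would move the number in either direction.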